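This account rests on a few compounds, and the source may have more. Where it says the series, first, only, none or still open, it means among the compounds named here.

Working notes on the naphthylethyl series in an ADME assay on HepG2 cells (Homo sapiens) for cytotoxicity, read by resazurin assay, with a stated time of 24 h; on this read-out lower numbers stand for higher toxicity in this test and higher numbers for lower toxicity in this test.

Compound 1 `CCN(CC)C(=O)c1c(O)cc(O)cc1CCc1ccc2ccccc2c1` gives 36400 nM in this assay. Its nearest measured neighbour is compound 3 `O=C(O)c1c(O)cc(Cl)cc1CCc1ccc2ccccc2c1` with 35000 nM; the two values sit within the scatter of each other, so the numbers for compound 1 and compound 3 cannot be told apart. Compound 2 `CCN(CC)C(=O)c1c(/C=C/c2ccc3ccccc3c2)cc(OC)cc1OC` returns only a limit in this assay, > 100000 nM, and no number; this is the limit of > 100000 nM in this assay, at which 1 of the 3 values shown sits. For the measured compounds named here, no pair of measured compounds differing in a single place is available, so the effect of any single change in this assay has not been measured within the set.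

Compound 4 `CCN(CC)C(=O)c1c(O)cccc1CCc1ccc2ccccc2c1` is not yet measured. It differs from compound 1 as follows: hydrogen in place of hydroxy on an aromatic carbon. Only compound 1, compound 3 and the limit for compound 2 inform the expectation, and none of them isolates a hydroxy. In this assay the expected step is none beyond the scatter in either direction. For compound 4 the estimate is 30000 nM, between 12000 nM and 80000 nM. This estimate means a step of a 1.2-fold lower number from compound 1 to compound 4 (0.08 log units; within the scatter), expected to stay within the scatter.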

Compound 4, half-maximal cytotoxic concentration: > 100000 nM
Compound 4 ended at the assay's limit (the forecaster's own chance of this, stated with the estimate: 10%); at least 3.3-fold (0.52 log units) between middle value and limit.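

Hydrogen in place of hydroxy on an aromatic carbon, para to a diethylcarbamoyl group, gives the first single-place step in the series: in this assay it is an at least 2.7-fold higher number from compound 1 to compound 4 (0.43 log units; beyond the scatter). The number for compound 1 therefore depends on this hydroxy, which the comparison of compound 1 with compound 3 could not isolate, and the hydroxy that remains in compound 4 does not bring the read-out down to a measurable number. The step has only a lower bound, as compound 4 gives a limit of the assay and not a number: the limit of > 100000 nM in this assay, at which 2 of the 4 values shown sit.

Going by these compounds, whether the step depends on the hydroxy itself or would also follow another replacement at this position, such as an amine or a fluorine, remains open. The contribution of the remaining hydroxy also remains unresolved.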